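Replacing the ethoxycarbonyl group of compound 2

The source may hold more compounds than are shown below. What is called first, only, known or untested is meant among the compounds shown, and "the series" means these compounds.

Two related compounds have been measured so far, and they differ in more than one place. In a functional assay on SK-BR-3 cells (Homo sapiens) for cytotoxicity, read by MTT assay, with a stated time of 72 h (a lower number here means that less compound is needed, a higher number that more compound is needed for the effect), compound 2 `CCOC(=O)c1c(C)coc1-c1ccc2c(CC)cccc2c1OC` gives 2.5 ug/mL, the higher of the two numbers. Compound 1 `CCc1cccc2c(O)c(-c3occ(C)c3C(=O)O)ccc12` gives 1 ug/mL, a lower number, and the gap between the two lies beyond the usual scatter of repeated measurements. Compound 2 therefore needs more material for the same effect.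

The next compound to be tested is compound 3 `CCc1cccc2c(OC)c(-c3occ(C)c3C(=S)OC)ccc12`. It keeps the shared core of compound 2, but the ethoxycarbonyl group gives way to a group of 4 heavy atoms containing sulfur, on an aromatic carbon: a group of 4 heavy atoms (2 carbon, 1 oxygen, 1 sulfur; no ring) in place of a group of 5 heavy atoms (3 carbon, 2 oxygen; no ring), on an aromatic carbon.

Within the data shown here, no pair of measured compounds differs in one place only, so nothing measured yet shows what such a swap does. The starting point is therefore compound 2 at 2.5 ug/mL. The expected step of no change at the digits printed from compound 2 to compound 3 (within the scatter) is none beyond the scatter, with no direction favoured. Compound 3 is estimated at 2.5 ug/mL, with an expected range from 1 ug/mL to 6 ug/mL.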

Compound 3, concentration for half-maximal effect: 6.3 ug/mL
Beside the measured number, compound 3's estimate is 2.5-fold (0.40 log units) below it; measured number above the stated range.
By their numbers in this assay, from the lowest: compound 1; then compound 2; then compound 3.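

Among these compounds, compounds 2 and 3 are the first pair here that differ in one place only, so this position on the five-membered aromatic ring can now be read directly. In this assay the swap of ethoxycarbonyl for the group of 4 heavy atoms containing sulfur gives a 2.5-fold higher number from compound 2 to compound 3 (0.40 log units; beyond the scatter) and so is a modest step towards needing more compound, even though both groups have no ring, 1 double bond outside aromatic rings, 0 hydrogen-bond donors, 2 hydrogen-bond acceptors and no net charge. The counts that do differ are those of the heavy atoms and the atoms of each element, and no measurement at hand explains the higher number.

This single swap changes the size of the group and brings in sulfur together, so the compounds shown cannot say how much of the step belongs to each. Also open, as far as these compounds go, is how this position would respond to a group of another kind, such as an amide or a nitrile, or to a longer chain on the ester in place of the ethyl.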